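Title: From a Cyclopropyl Ketone to a Methylphenyl Ketone

The compounds below may be only part of what the source reports. "The series", "measured", "known", "first", "only" and "open" are said of these compounds alone.

Measured compounds:
compound 1 `CCCCCC(=O)c1ccc(OCCCN2CCN(C(=O)c3c[nH]cn3)CC2)cc1`, 19500 nM
compound 2 `CCCCCC(=O)c1ccc(OCCCN2CCN(C(=O)CSCC)CC2)cc1`, 22900 nM
compound 3 `CCOC(=O)N1CCN(CCCOc2ccc(C(=O)C3CC3)cc2)CC1`, 79400 nM

In an assay on isolated protein for binding affinity to histamine H2 receptor (Homo sapiens) (a lower number here means a stronger inhibitor, a higher number a weaker inhibitor), compound 3 gives the highest of the three numbers. Its nearest neighbour is compound 2, and the gap between them lies beyond the scatter, as does the larger gap to compound 1. Compound 4 `CCOC(=O)N1CCN(CCCOc2ccc(C(=O)c3cccc(C)c3)cc2)CC1` differs from compound 3 in one place: 3-methylphenyl in place of cyclopropyl on a carbonyl carbon. Among the compounds with values here, no measured step touches this position. Within the data shown here, the only step available, a 1.2-fold higher number from compound 1 to compound 2 (0.07 log units; within the scatter), concerns a different part of the molecule and stayed within the scatter, so it offers no guide to the size or direction of the present change. Compounds 1 and 2 differ from compound 3 in more than one place, so their values cannot be read as a step either. The expectation for compound 4 therefore rests on compound 3 alone, and a modest shift, not confidently beyond the scatter, is estimated: a 1.6-fold lower number from compound 3 to compound 4 (0.20 log units; within the scatter). Compound 4 is thus expected to give 50000 nM, with a range from 15000 nM to 160000 nM.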

Compound 4, inhibition constant: 3720 nM
For compound 4 the middle estimate is 13-fold (1.13 log units) above the measured one; the measured number lies below the stated range.
By their numbers in this assay, from the lowest: compound 4; then compounds 1 and 2 (each within the scatter of the next); then compound 3.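

In this assay, within the data shown here, the position on the carbonyl carbon proves sensitive: 3-methylphenyl in place of cyclopropyl gives a 21-fold lower number from compound 3 to compound 4 (1.33 log units; beyond the scatter), the first measured change at this place. Among these compounds, the only earlier step, a 1.2-fold higher number from compound 1 to compound 2 (0.07 log units; within the scatter), concerned another part of the molecule and showed nothing about this position, whereas this exchange of a three-membered non-aromatic ring for a six-membered aromatic ring, with no hydrogen-bond donor or acceptor on either group, moves the number well beyond the scatter. Nothing given here accounts for the size of the step.

The compounds shown leave open whether the aromatic ring or its methyl carries the change, which a plain phenyl or a cyclohexyl on the same carbonyl carbon would help to separate. As far as these compounds go, it also remains open how a group such as an amine on that aromatic ring would read in this assay.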